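Thioether purine ribosides as inhibitors of nucleoside transport

A few compounds are considered here, and "the series" means these few. Any claim that something is new, unique, unknown or untested is made for them only; others in the source may bear on it.

Measured so far:
compound 1, `OC[C@H]1O[C@@H](n2cnc3c(SCC4CCCCC4)ncnc32)[C@H](O)[C@@H]1O`: 1550 nM
compound 2, `CCC(C)Sc1nc(N)nc2c1ncn2[C@@H]1O[C@H](CO)[C@@H](O)[C@H]1O`: 63100 nM

In an assay on isolated protein for binding affinity to Equilibrative nucleoside transporter 1 (Homo sapiens) (a higher number here means a weaker inhibitor, a lower number a stronger inhibitor), compound 2 gives the higher of the two numbers; compound 1 gives the lower one, and the gap lies beyond the scatter. Compound 3, `CC(=O)c1ccccc1Sc1nc(N)nc2c1ncn2[C@@H]1O[C@H](CO)[C@@H](O)[C@H]1O`, is not yet measured. It differs from compound 2 as follows: 2-acetylphenyl in place of sec-butyl on a sulfur. Among the compounds with values here, with no measured step of this kind to lean on, the step of a 7.9-fold lower number from compound 2 to compound 3 (0.90 log units; beyond the scatter) is expected to run toward a lower number and beyond the scatter, since compound 1 already shows that a larger substituent on that sulfur sits at 1550 nM. For compound 3 the estimate is 8000 nM, within 1500 nM to 40000 nM.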

Compound 3, half-maximal inhibitory concentration: 447000 nM
Compound 3: the middle estimate sits 56-fold (1.75 log units) below what was measured, outside the stated range (above it).
By their numbers in this assay, from the lowest: compound 1; then compound 2; then compound 3.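

In this assay the change from sec-butyl to 2-acetylphenyl on the sulfur gives a 7.1-fold higher number from compound 2 to compound 3 (0.85 log units; beyond the scatter) and so runs toward a weaker inhibitor. On the core shared by these two compounds, a larger substituent carrying an aromatic ring therefore does not by itself give a lower number at this position. Nothing measured accounts for this step.

An unsubstituted phenyl or a benzyl on the same sulfur would separate the effect of the acetyl group from that of the ring. As far as these compounds go, how a cyclohexylmethyl behaves on the core of compound 2 remains open.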